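Adding One Methyl to Compound 2

The compounds below may be only part of what the source reports. "The series", "measured", "known", "first", "only" and "open" are said of these compounds alone.

Compound 2 (`CCCCSc1nc(Cc2c(F)cccc2Cl)cc(=O)[nH]1`) carries a butyl chain on sulfur. In an ADME assay on MT4 cells (Homo sapiens) for activation, read by MTT assay (a lower number here means that less compound is tolerated, a higher number that more compound is tolerated), compound 2 gives > 76000 nM, which is a limit of the assay and not a number. Compound 1 (`CCC(C)Sc1nc(Cc2c(F)cccc2Cl)cc(=O)[nH]1`), with sec-butyl on the sulfur, gives > 76000 nM, again a limit. Compound 3 (`O=c1cc(Cc2c(F)cccc2Cl)nc(SC2CCCC2)[nH]1`), with cyclopentyl on the sulfur, gives > 74000 nM, also a limit.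

Compound 4 (`CCCCSc1nc(Cc2c(F)cccc2Cl)c(C)c(=O)[nH]1`) keeps the butyl chain of compound 2 and changes elsewhere: methyl in place of hydrogen on an aromatic carbon.

The measured steps all concern the group on sulfur: a step that the two limits leave unreadable from compound 1 to compound 2, a step that the two limits leave unreadable from compound 1 to compound 3 and a step that the two limits leave unreadable from compound 2 to compound 3. Their sizes cannot be read, since the values stand at the limit of > 76000 nM in this assay, at which 2 of the 3 values shown sit, and at the limit of > 74000 nM in this assay, at which 1 of the 3 values shown sits. None of these steps touches the aromatic carbon that gains the methyl, so they offer only indirect guidance. The expectation therefore starts from compound 2 at > 76000 nM. No step beyond the usual scatter is expected in this assay, and the estimated step is an at least 1.0-fold lower number from compound 2 to compound 4 (0.01 log units; that floor lies within the scatter). Compound 4 is estimated at 73000 nM, with an expected range of 30000 nM to 120000 nM.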

Compound 4, half-maximal cytotoxic concentration: > 73000 nM
Compound 4 was reported as a limit; the forecaster's own chance of this, stated with the estimate: 75%; the middle value lies on the limit itself.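

In this assay compound 4 gives > 73000 nM, a limit of the assay and not a number. Compound 2 also stands at a limit, and no step can be read between compound 2 and compound 4. The compounds shown leave open whether methyl in place of hydrogen on the aromatic carbon changes how much compound is tolerated.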